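Ethyl ester in place of the free acid: expected cytotoxicity

The compounds below may be only part of what the source reports. "The series", "measured", "known", "first", "only" and "open" are said of these compounds alone.

Compound 1, `CC(=O)Nc1cccc(-c2ccc(C(=O)N(Cc3cccc(OCCCCCC(=O)O)c3)C(C)C)cc2)c1`, gives in an ADME assay on BJ cells (Homo sapiens) for cytotoxicity, read by CellTiter-Glo and resazurin assay, with a stated time of 72 h (a lower number here means that less compound is needed, a higher number that more compound is needed for the effect), only a limit, > 26000 nM.
Compound 2, `CC(C)N(Cc1cccc(OCCCCCC(=O)O)c1)C(=O)c1ccc(-c2cccc(OCc3ccccc3)c2)cc1`, gives in this assay only a limit, > 26000 nM.
Compound 3, `CC(C)N(Cc1cccc(OCCCCCC(=O)O)c1)C(=O)c1ccc(-c2cccc(O)c2)cc1`, gives in this assay only a limit, > 26000 nM.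

Compound 2 therefore stands at the limit of this assay, like the other two: the limit of > 26000 nM in this assay, at which 3 of the 3 values shown sit. The three measured steps, a step that the two limits leave unreadable from compound 1 to compound 2, a step that the two limits leave unreadable from compound 1 to compound 3 and a step that the two limits leave unreadable from compound 2 to compound 3, all run between limits and give no readable size.

Compound 4, `CCOC(=O)CCCCCOc1cccc(CN(C(=O)c2ccc(-c3cccc(OCc4ccccc4)c3)cc2)C(C)C)c1`, differs from compound 2 at the chain end: ethyl in place of hydrogen on an oxygen next to a carbonyl group. Among the measured compounds shown here, none of the measured steps touches this oxygen next to a carbonyl group; they all change the group on the aromatic carbon of the distal ring. So no measured step bears directly on this change, and the only guidance is that every compound measured so far sits at the limit.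

The expectation for compound 4 is therefore again no readable effect in this assay, with the step from compound 2 to compound 4 estimated at a step that the limit leaves unreadable from compound 2 to compound 4. Compound 4 is expected at 40000 nM, within a range from 15000 nM to 120000 nM, most likely reported only as a limit.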

Compound 4, half-maximal effective concentration: > 26000 nM
Compound 4 was reported as a limit; the forecaster's own chance of this, stated with the estimate: 80%; the middle value does not contradict the limit.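

The step from carboxy to ethoxycarbonyl cannot be read, since compound 2 and compound 4 are both reported only as limits, not as numbers: the limit of > 26000 nM in this assay, at which 4 of the 4 values shown sit.

The compounds shown leave open at what concentration any of them would produce the effect in this assay, and whether the ethyl ester and the free acid differ there at all.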